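Urea aryl exchange on the shared core

The source may report more compounds than this note shows. Statements on the series, on what has been measured and on what is new or still open speak of the compounds shown alone.

Compound 1 `Cc1cccc(NC(=O)Nc2cccc(CNc3ncnc4ccccc34)c2)c1` is the unsubstituted member of the pair measured so far. In a functional assay on HepG2 cells (Homo sapiens) for antiproliferative activity, read by MTT assay (on this read-out higher numbers stand for weaker inhibition and lower numbers for stronger inhibition), compound 1 gives only a limit, > 50000 nM, and no number. Compound 2 `COc1ccccc1NC(=O)Nc1cccc(CNc2ncnc3cc(OC)c(OC)cc23)c1` carries the same urea linkage on a differently substituted shared core; in this assay compound 2 gives 27200 nM. Going by the values given here, that is the only number in the set: the other value shown is the limit (the limit of > 50000 nM in this assay, at which 1 of the 2 values shown sits). Compound 3 `COc1cc2ncnc(NCc3cccc(NC(=O)Nc4ccc([N+](=O)[O-])cc4)c3)c2cc1OC` keeps the core of compound 2 and changes the urea aryl: 4-nitrophenyl in place of 2-methoxyphenyl on an amide-type nitrogen. Among the compounds with values here, no step between measured compounds is available, so the size of this change is open, and the expected step is a 1.4-fold lower number from compound 2 to compound 3 (0.13 log units; within the scatter), within or close to the scatter, with no direction established. On that basis compound 3 is expected to give about 20000 nM in this assay, in the range 6000 nM to 60000 nM.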

Compound 3, half-maximal inhibitory concentration: 18800 nM
For compound 3 the middle estimate is 1.1-fold (0.03 log units) above the measured one; the range from low to high includes it.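

Going by these compounds alone, with the core of compound 2 held constant, the exchange of 2-methoxyphenyl for 4-nitrophenyl on the amide-type nitrogen gives the first readable step in this assay: a 1.4-fold lower number from compound 2 to compound 3 (0.16 log units; within the scatter). This single exchange therefore does not separate the two compounds, although both the group and the place of the substituent on the aryl ring change. Compound 1 differs from compound 3 in more than one place and gives no step, and its value is a limit and not a number: the limit of > 50000 nM in this assay, at which 1 of the 3 values shown sits.

What the compounds leave open is whether any group at this position moves the value beyond the scatter, for example an amine or a carboxylic acid on the urea aryl. Also open, on these data alone, is how 4-methoxyphenyl would compare, which would separate the effect of the substituent from that of its place on the ring.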